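Aryl swap on a triazole: cytotoxicity in liver cells

This account rests on a few compounds, and the source may have more. Where it says the series, first, only, none or still open, it means among the compounds named here.

Measured compounds:
Compound 1 `CC(C)=CCC/C(C)=C/CC/C(C)=C/CC[C@@H]1[C@@]2(C)CC/C(=N\OCc3cn(-c4ccc(F)c(Cl)c4)nn3)C(C)(C)[C@@H]2CC[C@@]1(C)O` gives 58900 nM in a functional assay on HepG2 cells (Homo sapiens) for cytotoxicity, read by MTT assay, with a stated time of 48 h; a lower number here means a stronger inhibitor, a higher number a weaker inhibitor.
Compound 2 `CC(C)=CCC/C(C)=C/CC/C(C)=C/CC[C@@H]1[C@@]2(C)CC/C(=N\OCc3cn(-c4c(Cl)cc([N+](=O)[O-])cc4Cl)nn3)C(C)(C)[C@@H]2CC[C@@]1(C)O` gives 34900 nM in this assay.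
Compound 3 `CC(C)=CCC/C(C)=C/CC/C(C)=C/CC[C@@H]1[C@@]2(C)C/C(=C\c3ccc(OCc4cn(-c5ccc(F)c(Cl)c5)nn4)cc3)C(=O)C(C)(C)[C@@H]2CC[C@@]1(C)O` gives 40200 nM in this assay.

Compound 1 and compound 2 share the same core and differ in a single place: 2,6-dichloro-4-nitrophenyl in place of 3-chloro-4-fluorophenyl on an aromatic nitrogen. That change produced a 1.7-fold lower number from compound 1 to compound 2 (0.23 log units; within the scatter), so the two numbers cannot be told apart with confidence. Compound 3 carries a different core; the difference between the two cores is not broken down here, and its value sits close to those of compound 1 and compound 2.

Compound 4 `CC(C)=CCC/C(C)=C/CC/C(C)=C/CC[C@@H]1[C@@]2(C)C/C(=C\c3ccc(OCc4cn(-c5c(Cl)cc([N+](=O)[O-])cc5Cl)nn4)cc3)C(=O)C(C)(C)[C@@H]2CC[C@@]1(C)O` has not yet been measured. It stands to compound 3 exactly as compound 2 stands to compound 1: 2,6-dichloro-4-nitrophenyl in place of 3-chloro-4-fluorophenyl on an aromatic nitrogen. The surroundings of the place are described in the same words for both pairs, so this is the same change, made a second time on the other core.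

Because the earlier pair showed a 1.7-fold lower number from compound 1 to compound 2 (0.23 log units; within the scatter), a step of similar, modest size is expected in this assay, namely a 1.7-fold lower number from compound 3 to compound 4 (0.22 log units; within the scatter). Compound 4 is therefore estimated at 24000 nM, with a likely range from 12000 nM to 60000 nM.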

Compound 4, half-maximal inhibitory concentration: 25100 nM
Estimate against measurement, compound 4: 1.0-fold (0.02 log units) below; the range from low to high includes it.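

In this assay, putting 2,6-dichloro-4-nitrophenyl in place of 3-chloro-4-fluorophenyl on the second core gives a 1.6-fold lower number from compound 3 to compound 4 (0.20 log units; within the scatter). Set beside the earlier pair, the change behaves alike on the two cores, and nothing here separates the size of one step from the other: the same change on two cores in this assay, a 1.7-fold lower number (0.23 log units; within the scatter) from compound 1 to compound 2 and a 1.6-fold lower number (0.20 log units; within the scatter) from compound 3 to compound 4, 1.1-fold (0.02 log units) apart, within the scatter of two such steps. Within the data shown here, this agreement shows only that the step did not visibly depend on the core in these two pairs; each step lies within the scatter, which means neither pair establishes a real effect of the swap, and two cores cannot show that the match would hold on a third.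

The compounds shown carry only these two substituted phenyl groups on the aromatic nitrogen, leaving open whether an aryl ring bearing an amine or a carboxylic acid, or a longer alkyl chain in place of the ring, would give a step beyond the scatter. Also open, as far as these compounds go, is how the same swap reads in any test other than this assay.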